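Compound 3: one stereocentre changed from compound 2

The source may report more compounds than this note shows. Statements on the series, on what has been measured and on what is new or still open speak of the compounds shown alone.

Measured in an ADME assay on HepG2 cells (Homo sapiens) for cytotoxicity, read by CellTiter-Glo, with a stated time of 72 h; on this read-out lower numbers stand for an effect already at smaller amounts and higher numbers for an effect only at larger amounts of compound:
- Compound 1 `CC1=C2CC(C)(C)/C=C/C/C(C)=C\C3=C[C@H](C)C[C@]3(O2)C1=O`: 26000 nM
- Compound 2 `CC1=C2CC(C)(C)/C=C/[C@H](O)/C(C)=C\C3=C[C@H](C)C[C@]3(O2)C1=O`: 18700 nM

For the measured compounds named here, on these two numbers, compound 2 stands level with compound 1, its only neighbour, within the scatter. Going by the values given here, the single measured step, hydroxy in place of hydrogen on a saturated ring carbon, is a 1.4-fold lower number from compound 1 to compound 2 (0.14 log units; within the scatter).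

Compound 3 `CC1=C2CC(C)(C)/C=C/[C@@H](O)/C(C)=C\C3=C[C@H](C)C[C@]3(O2)C1=O` has not yet been measured. Its relation to the previous compound is the two compounds have the same atoms and bonds and differ only in configuration as drawn: 1 of 5 stereo elements differ; a stereocentre at a saturated ring carbon is drawn S in compound 2 and R in compound 3: a stereocentre at a saturated ring carbon is drawn S in compound 2 and R in compound 3.

Among the compounds with values here, no measured pair differs only in configuration, so the evidence is indirect. Within the data shown here, with only that small step to go on, no shift beyond the scatter is expected in this assay. The expected step is a 1.1-fold higher number from compound 2 to compound 3 (0.03 log units; within the scatter). The estimate for compound 3 is 20000 nM, with an expected range of 10000 nM to 40000 nM.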

Compound 3, half-maximal effective concentration: 26000 nM
Compound 3: the middle estimate sits 1.3-fold (0.11 log units) below what was measured, within the range that was stated.
By their numbers in this assay, from the lowest: compounds 2, 1 and 3 (each within the scatter of the next).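

The earlier compounds shown here carried a hydroxy group on the saturated ring carbon in only one configuration, and now both configurations can be compared. In this assay the change from S to R at that carbon gives a 1.4-fold higher number from compound 2 to compound 3 (0.14 log units; within the scatter) and this comparison involves one difference only: the fact that compounds 2 and 3 differ only in the configuration as drawn. Hydroxy in place of hydrogen, now in the R configuration, gives no change at the digits printed from compound 1 to compound 3 (within the scatter) so at this position neither adding the hydroxy nor reversing its configuration moves the number beyond the scatter.

The compounds shown leave open whether another group on this carbon, such as an amine, a methoxy group or a carbonyl, would give a number beyond the scatter. Also open, going by these compounds, is whether a hydroxy elsewhere on the shared core would behave the same way.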